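Sulfonamide series: replacing the hydroxy group of compound 3

The source may hold more compounds than are shown below. What is called first, only, known or untested is meant among the compounds shown, and "the series" means these compounds.

Compound 3 `COc1cc(OC)c(/C=C/S(=O)(=O)Nc2ccc(OC)c(O)c2)c(OC)c1` gives the lowest of the three measured numbers in a functional assay on DU-145 cells (Homo sapiens) for cytotoxicity, read by trypan blue exclusion, with a stated time of 96 h (on this read-out higher numbers stand for weaker inhibition and lower numbers for stronger inhibition), at 30 nM. Compound 1 `COc1cc(OC)c(/C=C/S(=O)(=O)Nc2ccc(F)c(N)c2)c(OC)c1` gives 10000 nM and compound 2 `COc1ccc(NS(=O)(=O)/C=C/c2c(F)c(F)c(F)c(F)c2F)cc1F` gives 10000 nM. Among the measured compounds shown here, the one step that connects two measured compounds, a 330-fold lower number from compound 1 to compound 3 (2.52 log units; beyond the scatter), shows how far the group on the sulfonamide nitrogen can move the read-out.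

Compound 4 `COc1cc(OC)c(/C=C/S(=O)(=O)Nc2ccc(OC)c(NC(C(=O)O)c3ccc(Br)cc3)c2)c(OC)c1` differs from compound 3 in a single place: ((4-bromophenyl)(carboxy)methyl)amino in place of hydroxy on an aromatic carbon. For the measured compounds named here, no measured step touches this position, and the one known step concerns a different pair of groups on the sulfonamide nitrogen, so it is only a rough guide. Because compound 3 gives 30 nM with the hydroxy group in place and the step of a 330-fold lower number from compound 1 to compound 3 (2.52 log units; beyond the scatter) shows large movement from changes on this part of the molecule, a higher number is expected for compound 4, with wide uncertainty. In this assay compound 4 is estimated at 1000 nM, expected between 100 nM and 10000 nM. The expected step is a 33-fold higher number from compound 3 to compound 4 (1.52 log units; beyond the scatter), upward and beyond the scatter.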

Compound 4, half-maximal inhibitory concentration: 250 nM
Beside the measured number, compound 4's estimate is 4.0-fold (0.60 log units) above it, and the stated range covers the measured number.
By their numbers in this assay, from the lowest: compound 3; then compound 4; then compounds 1 and 2 (each within the scatter of the next).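

Among the compounds shown here, exchanging hydroxy for ((4-bromophenyl)(carboxy)methyl)amino in this assay gives an 8.3-fold higher number from compound 3 to compound 4 (0.92 log units; beyond the scatter) and is the first reading of this position on its own, since the earlier step from compound 1 to compound 3 changed two groups on the ring at once. The place ortho to a methoxy group therefore takes a group of 12 heavy atoms carrying its own aromatic ring, with a modest step that still lies beyond the scatter. Nothing at hand explains the direction or size of this step.

Which part of the entering group accounts for the step remains open. A plain amine at this place, a methyl ester in place of the carboxylic acid, or an unsubstituted phenyl ring in place of 4-bromophenyl would begin to separate these parts.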